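Bromo in Place of Trifluoromethyl on a Receptor Agonist

This account rests on a few compounds, and the source may have more. Where it says the series, first, only, none or still open, it means among the compounds named here.

Within the data shown here, compound 1 `Cc1cc(CCC(=O)O)ccc1-c1noc(-c2ccc(OC(C)C)c(C(F)(F)F)c2)n1` gives 40 nM in a functional assay on CHO cells for agonist activity at sphingosine 1-phosphate receptor 5 (Homo sapiens), read by GTPgammaS binding (on this read-out lower numbers stand for an effect already at smaller amounts and higher numbers for an effect only at larger amounts of compound), the lowest of the two numbers measured so far. Compound 2 `CCOc1ccc(-c2nc(-c3ccc(CCC(=O)O)cc3C)no2)cc1C(F)(F)F` gives 260 nM in this assay; the step of a 6.5-fold higher number from compound 1 to compound 2 (0.81 log units; beyond the scatter) concerns a different part of the molecule. Compound 3 `Cc1cc(CCC(=O)O)ccc1-c1noc(-c2ccc(OC(C)C)c(Br)c2)n1` is a new variant of compound 1: bromo in place of trifluoromethyl on an aromatic carbon. Among the measured compounds shown here, no measured step touches that aromatic position, so there is no direct guide to its effect. The step is therefore expected to be a 1.5-fold higher number from compound 1 to compound 3 (0.18 log units; within the scatter), likely within the scatter. Compound 3 is estimated at 60 nM, between 20 nM and 200 nM.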

Compound 3, half-maximal effective concentration: 43 nM
For compound 3 the middle estimate is 1.4-fold (0.14 log units) above the measured one; measured number inside the range.
By their numbers in this assay, from the lowest: compounds 1 and 3 (each within the scatter of the next); then compound 2.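

In this assay, a 1.1-fold higher number from compound 1 to compound 3 (0.03 log units; within the scatter) is all that bromo in place of trifluoromethyl brings on this aromatic carbon, ortho to an isopropoxy group. The earlier compounds shown here gave no reading at this position; here, one bromine atom serves as well as the 4 heavy atoms of trifluoromethyl, at least on this single read-out. Nothing at hand explains why the two groups match. As far as these compounds go, whether chloro, methyl or a nitrile on the same carbon would also keep the number in this range remains open.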